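Ethyl in Place of Amino on the Phenyl Terminus

This account rests on a few compounds, and the source may have more. Where it says the series, first, only, none or still open, it means among the compounds named here.

Compound 1 `CCCc1ccc(/C=C/C(=O)Nc2ccc3nc(CCC)cc(N)c3c2)cc1` and compound 2 `CCCc1cc(N)c2cc(NC(=O)/C=C/c3ccc(N)cc3)ccc2n1` share one amide core and differ at a single aromatic carbon. In an assay on isolated protein for displacement of a labelled ligand from melanin-concentrating hormone receptor 1 (Homo sapiens) (a higher number here means a weaker inhibitor, a lower number a stronger inhibitor), compound 1 gives 4 nM, whereas compound 2 gives 190 nM in this assay. Among the two measured numbers compound 2 stands highest, and its nearest neighbour is compound 1, separated by a 48-fold higher number from compound 1 to compound 2 (1.68 log units; beyond the scatter), a large step that left the usual scatter far behind.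

Compound 3 `CCCc1cc(N)c2cc(NC(=O)/C=C/c3ccc(CC)cc3)ccc2n1` is the next member of the series and has not been measured. Relative to compound 2 the change is ethyl in place of amino on an aromatic carbon. For the measured compounds named here, the only measured step that bears on it is a 48-fold higher number from compound 1 to compound 2 (1.68 log units; beyond the scatter), where a propyl chain gave way to the amino group at the same aromatic carbon. Ethyl is a carbon chain like the propyl of compound 1, so the step is expected to run back toward the lower numbers. Compound 3 is therefore expected to show a 24-fold lower number from compound 2 to compound 3 (1.38 log units; beyond the scatter) in this assay. Compound 3 is estimated at 8 nM, within a range from 3 nM to 30 nM.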

Compound 3, half-maximal inhibitory concentration: 1.4 nM
Compound 3: the middle estimate sits 5.7-fold (0.76 log units) above what was measured, outside the stated range (below it).
By their numbers in this assay, from the lowest: compound 3; then compound 1; then compound 2.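

At this aromatic carbon, the change from amino to ethyl gives a 140-fold lower number from compound 2 to compound 3 (2.13 log units; beyond the scatter) in this assay, so the high number of compound 2 is not a feature of the shared core: it goes with the amino group, and a short carbon chain more than restores the binding seen with propyl. The two carbon chains can also be told apart, since the move from propyl to ethyl gives a 2.9-fold lower number from compound 1 to compound 3 (0.46 log units; beyond the scatter), a modest step but one beyond the scatter, which shows that the full propyl length is not needed here and that the shorter chain gives the lower number of the pair. Among these three compounds, the two with a carbon chain sit low and compound 2 alone sits high, but nothing shown explains why amino and the chains differ so widely.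

The compounds shown leave open how the number runs with a methyl or a butyl group at this carbon, and two chain lengths cannot show whether ethyl is a best point or one point on a slope. They also leave open whether a methoxy or a dimethylamino group would fall with the carbon chains or with amino.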